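The source may hold more compounds than are shown below. What is called first, only, known or untested is meant among the compounds shown, and "the series" means these compounds.

In a functional assay on OVCAR-3 cells (Homo sapiens) for antiproliferative activity, read by spectrophotometry, with a stated time of 2 days (on this read-out lower numbers stand for stronger inhibition of growth and higher numbers for weaker inhibition of growth), compound 1 `COc1ccc(C(F)(F)F)cc1Nc1ncc(C(F)(F)F)c(N2Cc3cccc(N(C)S(C)(=O)=O)c3C2)n1` gives only a limit, > 30000 nM, and no number. Compound 3 `CN(c1cccc2c1CN(c1nc(Nc3cc(C(F)(F)F)cc(C(F)(F)F)c3)ncc1C(F)(F)F)C2)S(C)(=O)=O` likewise gives only a limit, > 30000 nM. Compound 2 `CN(c1cccc2c1CN(c1nc(Nc3cccc(Oc4ccccc4)c3)ncc1C(F)(F)F)C2)S(C)(=O)=O` gives a measured 24900 nM. The picture is thus dominated by the limit of > 30000 nM in this assay, at which 2 of the 3 values shown sit. Compound 4 `Cc1ccc(Nc2ncc(C(F)(F)F)c(N3Cc4cccc(N(C)S(C)(=O)=O)c4C3)n2)c(C)c1` carries 2,4-dimethylphenyl in place of 2-methoxy-5-(trifluoromethyl)phenyl on a nitrogen on an aromatic ring. Within the data shown here, no measured pair isolates this change, so any expectation in this assay remains loose, and no shift beyond the usual scatter is expected in either direction. The estimated move is an at least 1.0-fold lower number from compound 1 to compound 4 (0.02 log units; that floor lies within the scatter). For compound 4 the expected value is 28000 nM, with an estimated range from 12000 nM to 45000 nM.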

Compound 4, concentration for 50% growth inhibition: > 30000 nM
Compound 4: only a limit was reported; the forecaster's own chance of this, stated with the estimate: 55%; middle value at least 1.0-fold (0.02 log units) away from the limit.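

In this assay compound 4 gives > 30000 nM, a limit and not a number. Among these compounds, compound 1 also gives only a limit, and no step between compound 1 and compound 4 can be read. The compounds shown leave open whether 2,4-dimethylphenyl in place of 2-methoxy-5-(trifluoromethyl)phenyl changes growth inhibition at all.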